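Cytotoxicity notes: from compound 3 to compound 4

The compounds below may be only part of what the source reports. "The series", "measured", "known", "first", "only" and "open" are said of these compounds alone.

Measured in an ADME assay on Huh-7 cells (Homo sapiens) for cytotoxicity, read by MTT assay, with a stated time of 48 h; a lower number here means that less compound is tolerated, a higher number that more compound is tolerated:
- compound 1, `CN(C)CCCCN(C(=O)O)c1ccccc1Cn1nc(-c2ccc(F)cc2)c2ccccc2c1=O`, 48500 nM
- compound 2, `CN(C)CCCC(=O)Nc1ccc(CN2N=C(c3ccc(F)cc3)C3C=CC=CC3C2=O)cc1`, 38200 nM
- compound 3, `CN(C)CCCCOC(=O)Nc1ccc(Cn2nc(-c3ccncc3)c3ccccc3c2=O)cc1`, 62700 nM

Compound 3 gives the highest of the three numbers, yet its gaps to compound 1 and to compound 2 both lie within the scatter, so the three measured compounds cannot be ordered on these data. Compound 4, `CN(C)CCCCOC(=O)Nc1ccc(Cn2nc(-c3cccc(C#N)c3)c3ccccc3c2=O)cc1`, has not been measured. Its structural change from compound 3 is 3-cyanophenyl in place of pyridin-4-yl on an aromatic carbon. Within the data shown here, no step between measured compounds resembles this exchange, so nothing measures its effect. The step of a 1.3-fold lower number from compound 3 to compound 4 (0.10 log units; within the scatter) is expected to stay within the scatter. Compound 4 is estimated at 50000 nM, with a range from 25000 nM to 100000 nM.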

Compound 4, half-maximal cytotoxic concentration: 17200 nM
Beside the measured number, compound 4's estimate is 2.9-fold (0.46 log units) above it; the whole stated range lies above it.
By their numbers in this assay, from the lowest: compound 4; then compounds 2, 1 and 3 (each within the scatter of the next).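

In this assay the exchange of pyridin-4-yl for 3-cyanophenyl gives a 3.6-fold lower number from compound 3 to compound 4 (0.56 log units; beyond the scatter) with nothing else in the structure altered, so this aromatic carbon is a place where the number can move beyond the scatter. The earlier compounds shown here, all within the scatter of one another and with no pair differing in one place, could not show this. The step joins two changes, loss of the ring nitrogen and arrival of the nitrile, and cannot be assigned to either.

Unsubstituted phenyl or pyridin-3-yl on this carbon would separate the two. No measurement at hand gives a cause for the step.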